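This account rests on a few compounds, and the source may have more. Where it says the series, first, only, none or still open, it means among the compounds named here.

Of the compounds shown here, two sharing one core have been tested in a functional assay on the whole organism (strain Swiss albino) for inhibition, with Mus musculus as the target, in the writhing test, with a stated time of 30 min, at a dose of 10 mg/kg by the oral route; a lower number here means a weaker effect, a higher number a stronger effect of the compound at the dose given. Going by the values given here, compound 1, `Cc1c(/C=N\O)cc(-c2ccc(S(C)(=O)=O)cc2)n1-c1ccccc1`, is the first of them, and in this assay compound 1 gives 27%. Compound 2, `Cc1c(C#N)cc(-c2ccc(S(C)(=O)=O)cc2)n1-c1cccc(F)c1`, is the second, and in this assay compound 2 gives 28%. On the numbers shown, compound 2 sits alongside compound 1: the two read-outs lie within the usual scatter of repeated measurements, so nothing separates them. Among the compounds with values here, compound 1 and compound 2 differ from each other in more than one place, so no single-change step between measured compounds is available.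

Compound 3, `Cc1c(C#N)cc(-c2ccc(S(C)(=O)=O)cc2)n1-c1ccccc1`, has not yet been measured. It differs from compound 2 in exactly one place: hydrogen in place of fluoro on an aromatic carbon. Since the measured pair differs in two places, the effect of this one change alone cannot be read from compound 1 and compound 2. The step from compound 2 to compound 3 is expected to be small, a number 1 percentage points lower from compound 2 to compound 3 (within the scatter), in no firm direction and not beyond the scatter. Compound 3 is expected to give about 27% in this assay, with a range from 15% to 40%.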

Compound 3, a percentage reported as inhibition, in the whole organism at one dose (the size of the read-out at that dose, not a potency): 28%
Compound 3: the middle estimate sits 1 percentage points below what was measured; measured number inside the range.
By their numbers in this assay, from the lowest: compounds 1, 2 and 3 (each within the scatter of the next).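

In this assay, the change from 3-fluorophenyl to phenyl can now be read alone, and it gives no change at the digits printed from compound 2 to compound 3 (within the scatter); at this dose, fluoro and hydrogen on this aromatic carbon cannot be told apart. Going by these compounds alone, compound 3 also isolates the other difference between the earlier compounds, with nitrile in place of the oxime on an aromatic carbon, and this step reads a number 1 percentage points higher from compound 1 to compound 3 (within the scatter). Compound 1 and compound 2 differed in two places at once, so their similar values could have hidden two opposing effects, but each change taken alone now stays within the scatter.

No measurement shown here offers an explanation for why these read-outs stay together. From the compounds shown here alone, it remains open whether a methoxy group or an amine on that same aromatic carbon, or a carboxylic acid in place of the nitrile, would move the read-out beyond the scatter, and whether these compounds would still match at other doses, as a read-out at one dose gives the size of the effect and not a potency.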